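The source may report more compounds than this note shows. Statements on the series, on what has been measured and on what is new or still open speak of the compounds shown alone.

Measured so far: compound 1 `Cn1cnc2ccc(-c3cc(F)c(Cn4cnc5cnccc5c4=O)c(F)c3)cc21` with 0.04; compound 2 `Cn1cc2c(-c3cc(F)c(Cn4c(=O)cnc5ccccc54)c(F)c3)cccc2n1` with 0.01; compound 3 `Cn1cc2c(-c3cc(F)c(CN4C=CC5=NCCN5C4=O)c(F)c3)cccc2n1` with 0.08.

In an ADME assay on a cell-free system (plasma, Rattus norvegicus) for protein binding (a higher number here means a larger unbound share of the compound, a lower number a smaller unbound share), compound 1 sits second highest of the three numbers; compound 3 gives a number within the scatter of it, while compound 2 lies lower by a gap beyond the scatter. Compound 4 `Cn1cc2c(-c3cc(F)c(Cn4cnc5cnccc5c4=O)c(F)c3)cccc2n1` is not yet measured. It differs from compound 1 by 2-methyl-2H-indazol-4-yl in place of 1-methyl-1H-benzimidazol-6-yl on an aromatic carbon. For the measured compounds named here, no measured pair isolates this change; compounds 2 and 3 both carry the entering group combined with other groups elsewhere, and their numbers in this assay bracket that of compound 1. The step of a 1.3-fold lower number from compound 1 to compound 4 (0.12 log units; within the scatter) is therefore expected to be none beyond the scatter. For compound 4 an unbound fraction of 0.03 is estimated, in the range 0.01 to 0.08.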

Compound 4, unbound fraction: 0.01
Estimate against measurement, compound 4: 3.0-fold (0.48 log units) above, within the range that was stated.
By their numbers in this assay, from the lowest: compounds 2 and 4 (each within the scatter of the next); then compounds 1 and 3 (each within the scatter of the next).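

In this assay, for the compounds shown here, the aromatic carbon para to a large group proves sensitive to this exchange: 2-methyl-2H-indazol-4-yl in place of 1-methyl-1H-benzimidazol-6-yl gives a 4.0-fold lower number from compound 1 to compound 4 (0.60 log units; beyond the scatter) as the first single-place step. The two groups have the same atoms and the same ring and hydrogen-bond counts, so the step separates isomers only. Nothing available accounts for this step.

As far as these compounds go, whether the same exchange gives a similar step alongside the other groups carried by compound 2 and compound 3 remains open. Also open, from the compounds shown here alone, is how a carboxylic acid or an amine on the 2-methyl-2H-indazol-4-yl group would read in this assay.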